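A few compounds are considered here, and "the series" means these few. Any claim that something is new, unique, unknown or untested is made for them only; others in the source may bear on it.

Compound 1 `COc1ccc2c(=O)c(/C=C/C(=O)NCc3ccccc3)coc2c1`: 376000 nM
Compound 2 `COc1ccc(CNC(=O)/C=C/c2coc3cc(OC)ccc3c2=O)cc1`: 43000 nM

In an ADME assay on HepG2 2.2.15 cells (Homo sapiens) for cytotoxicity, read by MTT assay, with stated times of 48 h and 9 days (a higher number here means that more compound is tolerated, a lower number that less compound is tolerated), compound 2 gives the lower of the two numbers, and its nearest neighbour is compound 1, which is an 8.7-fold lower number from compound 1 to compound 2 (0.94 log units; beyond the scatter) away. Compound 3 `COc1ccc2c(=O)c(/C=C/C(=O)Nc3ccc(C)cc3)coc2c1` differs from compound 2 by 4-methylphenyl in place of 4-methoxybenzyl on an amide-type nitrogen. Going by the values given here, the only measured step, an 8.7-fold lower number from compound 1 to compound 2 (0.94 log units; beyond the scatter), went with adding a methoxy group; in compound 3 the methoxy group leaves again, alongside a larger reshaping. A move back upward is therefore expected, though its size is uncertain. For compound 3 the estimate is 150000 nM, with a range from 40000 nM to 450000 nM, a step of a 3.5-fold higher number from compound 2 to compound 3 (0.54 log units; beyond the scatter).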

Compound 3, half-maximal cytotoxic concentration: 979000 nM
Estimate against measurement, compound 3: 6.5-fold (0.81 log units) below; measured number outside the range, above it.
By their numbers in this assay, from the lowest: compound 2; then compound 1; then compound 3.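

Changing the group on the amide-type nitrogen moves the number in this assay further than adding the methoxy group did: the change to 4-methylphenyl gives a 23-fold higher number from compound 2 to compound 3 (1.36 log units; beyond the scatter) and, against plain benzyl, a 2.6-fold higher number from compound 1 to compound 3 (0.42 log units; beyond the scatter) as well. Nothing measured here explains why this position responds so strongly. As far as these compounds go, compound 3 replaces benzyl with a methyl-bearing phenyl ring in a single change, so the share of the methyl group in this rise stays open. Unsubstituted phenyl, or an amine or carboxylic acid on that ring, could show how far the trend extends.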